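Swapping a pyridine for a chlorophenyl on the amide

This account rests on a few compounds, and the source may have more. Where it says the series, first, only, none or still open, it means among the compounds named here.

Four compounds share one core and differ only in the group carried on the amide nitrogen. Compound 2 `COc1ccc(C(=O)Nc2ccncc2)cc1Nc1nccc(-c2cccnc2)n1` carries a pyridin-4-yl group there, and in a functional assay on K562 cells (Homo sapiens) for antiproliferative activity, read by MTT assay, with a stated time of 48 h (a higher number here means a weaker inhibitor, a lower number a stronger inhibitor), compound 2 gives 94500 nM. Compound 3 `COc1ccc(C(=O)Nc2ccc(OCCCN(C)C)cc2)cc1Nc1nccc(-c2cccnc2)n1` carries a different group in the same place, and in this assay compound 3 gives 38500 nM. Of the two numbers reported, compound 2 has the higher one, and its gap to compound 3 is wider than the usual scatter, so compound 2 is the weaker inhibitor of that pair. Compound 1 `COc1ccc(C(=O)Nc2cccc(F)c2)cc1Nc1nccc(-c2cccnc2)n1` in this assay gives "not determined" (no result reported). Compound 4 `COc1ccc(C(=O)Nc2cccc(Cl)c2)cc1Nc1nccc(-c2cccnc2)n1` has not yet been measured. It differs from compound 2 in one place: 3-chlorophenyl in place of pyridin-4-yl on an amide-type nitrogen. Within the data shown here, no measured pair isolates this kind of exchange, so the direction of the step is uncertain, and only a modest move towards a lower number is expected. Compound 4 is expected to give 50000 nM in this assay, with a range from 10000 nM to 200000 nM. Expressed as a step, this expectation reads a 1.9-fold lower number from compound 2 to compound 4 (0.28 log units; within the scatter).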

Compound 4, half-maximal inhibitory concentration: 237000 nM
Beside the measured number, compound 4's estimate is 4.7-fold (0.68 log units) below it, outside the stated range (above it).
By their numbers in this assay, from the lowest: compound 3; then compound 2; then compound 4.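

In this assay, replacing pyridin-4-yl with 3-chlorophenyl on the amide-type nitrogen gives a 2.5-fold higher number from compound 2 to compound 4 (0.40 log units; beyond the scatter), so the step points towards weaker inhibition. Among these compounds, this is the first measured pair here that isolates one aromatic ring for another at this place, and it shows that the activity responds to this exchange, with the carbon-only ring carrying chlorine on the weaker side. Nothing in the available data explains the direction of this step.

The exchange removes the ring nitrogen and adds the chlorine at once, so the two changes cannot be separated, and a plain phenyl group would be needed to tell them apart. Also open, as far as these compounds go, is how a carboxylic acid or a methoxy group on this ring would read in this assay.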